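Compound 4 and the Return to a Small Halogen

The source may report more compounds than this note shows. Statements on the series, on what has been measured and on what is new or still open speak of the compounds shown alone.

The series shares the core of compound 1 `CC(C)N(Cc1ccc(OC(F)(F)F)cc1)[C@@H]1COc2nc([N+](=O)[O-])cn2C1`. In a physicochemical assay for solubility, at pH 6.8 (on this read-out lower numbers stand for lower solubility and higher numbers for higher solubility), compound 1 gives only a limit, < 2 ug/mL. Compound 2 `O=[N+]([O-])c1cn2c(n1)OC[C@@H](NCc1ccc(OC(F)(F)F)cc1F)C2` gives 72 ug/mL in this assay, and compound 3 `O=[N+]([O-])c1cn2c(n1)OC[C@@H](NCc1ccc(OC(F)(F)F)cc1OCC1CC1)C2` gives 6 ug/mL, the lowest of the two numbers. Among the measured compounds shown here, the only measured step is a 12-fold lower number from compound 2 to compound 3 (1.08 log units; beyond the scatter). Compound 4 `O=[N+]([O-])c1cn2c(n1)OC[C@@H](NCc1ccc(OC(F)(F)F)cc1Cl)C2` differs from compound 3 by chloro in place of cyclopropylmethoxy on an aromatic carbon. Because the change removes the group whose entry lowered the number in a 12-fold lower number from compound 2 to compound 3 (1.08 log units; beyond the scatter), a rise is expected, but since chloro rather than fluoro enters, the estimated step of a 4.2-fold higher number from compound 3 to compound 4 (0.62 log units; beyond the scatter) is taken as smaller than a full reversal. For compound 4 the expected number in this assay is 25 ug/mL, with a range from 6 ug/mL to 80 ug/mL.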

Compound 4, solubility: 30 ug/mL
Compound 4: middle estimate off by 1.2-fold (0.08 log units), on the low side; measured number inside the range.
By their numbers in this assay, from the lowest: compound 3; then compound 4; then compound 2. At a limit, below all of these: compound 1.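

Chloro in place of cyclopropylmethoxy gives a 5.0-fold higher number from compound 3 to compound 4 (0.70 log units; beyond the scatter) and so takes back part of the fall that came with cyclopropylmethoxy at this position. The two halogens do not read alike here: chloro in place of fluoro gives a 2.4-fold lower number from compound 2 to compound 4 (0.38 log units; beyond the scatter) and leaves compound 4 short of compound 2. Nothing measured here gives a cause for either step.

On these data alone, what this assay would give with an amine or a carboxylic acid at this position stays open. Also open, as far as these compounds go, is whether the number follows the size of the entering group, with only fluoro, chloro and cyclopropylmethoxy to compare.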